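The source may report more compounds than this note shows. Statements on the series, on what has been measured and on what is new or still open speak of the compounds shown alone.

Of the compounds shown here, two have so far been measured in a functional assay on MDA-MB-231 cells (Homo sapiens) for cytotoxicity, read by MTT assay, with a stated time of 72 h; a lower number here means a stronger inhibitor, a higher number a weaker inhibitor. Compound 1 `CN(C)CCCNc1nc(-c2ccc(NC(=O)Nc3ccc(Cl)cc3)cc2)nc2c(Cl)c(Cl)sc12` gives 1160 nM in this assay. Compound 2 `CN(C)CCNc1nc(-c2ccc(NC(=O)Nc3ccc(F)cc3)cc2)nc2c(Cl)c(Cl)sc12` gives 1240 nM; of the two numbers it is the one standing nominally at the top, yet compound 1 lies within the scatter of it, so the pair cannot be told apart in this assay. Compound 3 `CN(C)CCNc1nc(-c2ccc(NC(=O)Nc3ccc(Cl)cc3)cc2)nc2c(Cl)c(Cl)sc12` has not yet been measured. It differs from compound 2 in one place: chloro in place of fluoro on an aromatic carbon. Among the compounds with values here, no step between measured compounds isolates this change. Compound 1 also carries the chloro group but differs from compound 3 in its chain as well, so the value of compound 1, 1160 nM, gives only a loose hint. The expected step is a 1.1-fold lower number from compound 2 to compound 3 (0.05 log units; within the scatter), nothing beyond the scatter. Compound 3 is therefore estimated at 1100 nM, with a range from 500 nM to 2500 nM.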

Compound 3, half-maximal inhibitory concentration: 870 nM
The estimate for compound 3 lay 1.3-fold (0.10 log units) above the measured number; measured number inside the range.
By their numbers in this assay, from the lowest: compounds 3, 1 and 2 (each within the scatter of the next).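

In this assay, within the data shown here, the first direct comparison at this position, chloro in place of fluoro on the aromatic carbon para to a large group gives a 1.4-fold lower number from compound 2 to compound 3 (0.15 log units; within the scatter), so the 4-chlorophenyl and 4-fluorophenyl compounds cannot be told apart. The chain now has a comparison of its own: dimethylamino in place of (dimethylamino)methyl on the saturated chain carbon gives a 1.3-fold lower number from compound 1 to compound 3 (0.12 log units; within the scatter), and this change also leaves the compounds indistinguishable in this assay. No available evidence bears on these results.

From the compounds shown here alone, whether a methoxy or trifluoromethyl group at this ring position would give a step beyond the scatter remains open. The same question stands for a longer chain or a morpholine in place of the dimethylamino group.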